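The source may hold more compounds than are shown below. What is called first, only, known or untested is meant among the compounds shown, and "the series" means these compounds.

Within the data shown here, compound 1 `COc1cccc(NC(=O)Nc2ccc(Oc3ncnc4[nH]ncc34)cc2)c1` is the only compound with a number in an assay on isolated protein for inhibition of vascular endothelial growth factor receptor 2 (Danio rerio), read by fluorescence and microscopy, with a stated time of 33 h (a higher number here means a weaker inhibitor, a lower number a stronger inhibitor), where compound 1 gives 82000 nM. Compound 2 `COc1cccc(NC(=O)Nc2ccc(Oc3ncnc4c3cnn4C)cc2)c1` reaches only a limit in this assay, > 100000 nM. Among the measured compounds shown here, the one measured step, an at least 1.2-fold higher number from compound 1 to compound 2 (0.08 log units; that floor lies within the scatter), concerns a methyl in place of hydrogen on an aromatic nitrogen and says nothing about the urea side. Compound 3 `O=C(NCC1CCCCC1)Nc1ccc(Oc2ncnc3[nH]ncc23)cc1` differs from compound 1 by cyclohexylmethyl in place of 3-methoxyphenyl on an amide-type nitrogen. For the measured compounds named here, no measured step bears on this change, so the expected step of a 1.2-fold higher number from compound 1 to compound 3 (0.09 log units; within the scatter) rests on the weak level of compound 1 alone. Compound 3 is estimated at 100000 nM, range 30000 nM to 300000 nM.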

Compound 3, half-maximal inhibitory concentration: > 100000 nM
Compound 3: no number, only a limit; the forecaster's own chance of this, stated with the estimate: 50%; the middle value lies on the limit itself.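

Compound 3 gives only a limit in this assay, > 100000 nM. The amide-type nitrogen now has its first reading: cyclohexylmethyl in place of 3-methoxyphenyl gives an at least 1.2-fold higher number from compound 1 to compound 3 (0.08 log units; that floor lies within the scatter), so no order between the two can be drawn. Both single changes from compound 1 shown so far, at two different places, end at a limit: the limit of > 100000 nM in this assay, at which 2 of the 3 values shown sit.

From the compounds shown here alone, how far the step extends beyond its floor stays open. Also open, going by these compounds, is how a phenyl carrying an amine or a carboxylic acid, or a longer carbon chain, would read on this amide-type nitrogen.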